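Aryl-amine swap on a weakly cytotoxic quinazoline scaffold

The source may hold more compounds than are shown below. What is called first, only, known or untested is meant among the compounds shown, and "the series" means these compounds.

Compound 1 `COc1ccc(Nc2nc(-c3cccc(F)c3)nc3ccc(F)cc23)cc1`: 48400 nM
Compound 2 `Fc1cccc(-c2nc(Nc3ccccc3F)c3cc(F)ccc3n2)c1`: > 50000 nM

In a functional assay on MCF7 cells (Homo sapiens) for cytotoxicity, read by MTT assay, with a stated time of 48 h (on this read-out lower numbers stand for stronger inhibition and higher numbers for weaker inhibition), compound 1 gives 48400 nM. Compound 2 reaches only the assay limit, > 50000 nM, which is a limit and not a number (the limit of > 50000 nM in this assay, at which 1 of the 2 values shown sits). Within the data shown here, the step of an at least 1.0-fold higher number from compound 1 to compound 2 (0.01 log units; that floor lies within the scatter) therefore tells only that the two compounds stand close together. Compound 3 `Fc1cccc(-c2nc(Nc3ccc(Cl)cc3)c3cc(F)ccc3n2)c1` differs by 4-chlorophenyl in place of 2-fluorophenyl on a nitrogen on an aromatic ring. Among the measured compounds shown here, only the step from compound 1 to compound 2 bears on this change, and it lay within the scatter, so no step beyond the scatter is expected, as a number no higher from compound 2 to compound 3 (the limit leaves the size open). Compound 3 is thus estimated at 50000 nM, from 20000 nM to 150000 nM.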

Compound 3, half-maximal inhibitory concentration: > 50000 nM
Compound 3 gave a limit, no number; the forecaster's own chance of this, stated with the estimate: 55%; the middle value sits exactly at the limit.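

With 4-chlorophenyl on a nitrogen on an aromatic ring, compound 3 also ends at a limit and not a number in this assay, so a second group in this place gives no readable value, and the step between compound 2 and compound 3 cannot be read. Chloro in place of methoxy gives an at least 1.0-fold higher number from compound 1 to compound 3 (0.01 log units; that floor lies within the scatter), so this change shows no step beyond the scatter. Most values shown sit at the same limit: the limit of > 50000 nM in this assay, at which 2 of the 3 values shown sit.

What the compounds shown leave open is whether any group in this place brings a value clearly under that limit. On these data alone, an amine or a carboxylic acid on this phenyl ring remains untested among them.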